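A few compounds are considered here, and "the series" means these few. Any claim that something is new, unique, unknown or untested is made for them only; others in the source may bear on it.

Compound 1 `COc1cc(C(=O)c2sc3ccccc3c2-c2ccccc2)cc(OC)c1OC` is the starting point of this comparison. In a functional assay on HL-60 cells (Homo sapiens) for antiproliferative activity, read by MTT assay, with a stated time of 72 h (a lower number here means a stronger inhibitor, a higher number a weaker inhibitor), compound 1 gives 1700 nM, the lowest of the two numbers shown, with compound 3 `COc1cc(C(=O)c2sc3ccccc3c2Nc2ccc(Cl)cc2)cc(OC)c1OC` as its nearest neighbour at 5400 nM in this assay. Compound 2 `COc1ccc(OC)c(-c2c(C(=O)c3cc(OC)c(OC)c(OC)c3)sc3ccccc23)c1` gives in this assay only a limit, > 10000 nM (the limit of > 10000 nM in this assay, at which 1 of the 3 values shown sits).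

Compound 4 `COc1cc(C(=O)c2sc3ccccc3c2Nc2ccc(C)cc2)cc(OC)c1OC` differs from compound 1 in one place: (4-methylphenyl)amino in place of phenyl on an aromatic carbon. The measured step that bears most directly on this change is a 3.2-fold higher number from compound 1 to compound 3 (0.50 log units; beyond the scatter), in which the same (4-chlorophenyl)amino type of group enters on the same aromatic carbon, carrying a chloro group where compound 4 carries a methyl group. The step of an at least 5.8-fold higher number from compound 1 to compound 2 (0.76 log units; beyond the scatter) concerns a different kind of replacement and reaches only a limit, so it is a weaker guide. Taking the step to compound 3 as the closest precedent, a modest rise in the number, in the direction of weaker inhibition, is expected for compound 4 as well, since compound 3 gives 5400 nM in this assay. Compound 4 is therefore estimated to give around 5000 nM in this assay, within a range from 2000 nM to 15000 nM. The expected step is a 2.9-fold higher number from compound 1 to compound 4 (0.47 log units; beyond the scatter).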

Compound 4, half-maximal inhibitory concentration: 4600 nM
Compound 4: the middle estimate sits 1.1-fold (0.04 log units) above what was measured; the range from low to high includes it.
By their numbers in this assay, from the lowest: compound 1; then compounds 4 and 3 (each within the scatter of the next). At a limit, above all of these: compound 2.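

With (4-methylphenyl)amino on this aromatic carbon, this assay gives a 2.7-fold higher number from compound 1 to compound 4 (0.43 log units; beyond the scatter), so the rise in the number on leaving phenyl is no longer seen with the (4-chlorophenyl)amino group of compound 3 alone. Methyl in place of chloro gives a 1.2-fold lower number from compound 3 to compound 4 (0.07 log units; within the scatter), so these two groups on the ring of the amino substituent cannot be told apart in this assay, and the shift away from phenyl is the larger effect in this small set. The step of an at least 2.1-fold lower number from compound 2 to compound 4 (0.33 log units; beyond the scatter) now clears the scatter, unlike the floor of the step to compound 3, but it is read against a value that is only a limit: the limit of > 10000 nM in this assay, at which 1 of the 4 values shown sits.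

The compounds shown leave open whether a different group on that ring, such as methoxy, hydroxyl or dimethylamino, would move the number further than chloro and methyl do. They also do not separate the part played by the ring from that played by the linking nitrogen, which a plain phenylamino group, a benzyl group or an N-methyl amine in the same place could help to settle.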